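A few compounds are considered here, and "the series" means these few. Any claim that something is new, unique, unknown or untested is made for them only; others in the source may bear on it.

In an in vitro ADME assay on microsomes (Mus musculus) for metabolic stability (a higher number here means that the compound lasts longer, a lower number that the compound disappears faster), compound 1 `CC(=O)N1CCc2c(C)c3c(n2-c2ccc(C(N)=O)c(c2)N[C@@H](C)[C@H](C)C1)CC(C)(C)CC3=O` gives 0.0667 h, while compound 2 `Cc1c2c(n3c1CCN(C(=O)C(C)(C)N)C[C@@H](C)[C@H](C)Nc1cc-3ccc1C(N)=O)CC(C)(C)CC2=O` gives 0.367 h, the higher of the two numbers. Compound 3 `Cc1c2c(n3c1CCN(C(=O)C1(N)CCCC1)C[C@@H](C)[C@H](C)Nc1cc-3ccc1C(N)=O)CC(C)(C)CC2=O` differs from compound 2 on a carbonyl carbon: 1-aminocyclopentyl in place of 1-amino-1-methylethyl on a carbonyl carbon. Among the compounds with values here, only one measured step bears on this, a 5.5-fold higher number from compound 1 to compound 2 (0.74 log units; beyond the scatter), with 1-amino-1-methylethyl in place of methyl. Within the data shown here, with that step as the only guide, and with 1-aminocyclopentyl keeping the amino group, a much smaller step is expected in this assay, probably none beyond the scatter. The expected change is a 1.5-fold lower number from compound 2 to compound 3 (0.17 log units; within the scatter). For compound 3 the estimate is 0.25 h, with an expected range of 0.1 h to 0.6 h.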

Compound 3, half-life: 0.0833 h
Compound 3: the middle estimate sits 3.0-fold (0.48 log units) above what was measured; the measured number lies below the stated range.
By their numbers in this assay, from the lowest: compounds 1 and 3 (each within the scatter of the next); then compound 2.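

In this assay, keeping the amino group on this carbonyl carbon does not by itself keep the higher number: 1-aminocyclopentyl in place of 1-amino-1-methylethyl gives a 4.4-fold lower number from compound 2 to compound 3 (0.64 log units; beyond the scatter) on this change. With 1-aminocyclopentyl in place of methyl there is a 1.2-fold higher number from compound 1 to compound 3 (0.10 log units; within the scatter) and thus no gain, so among these three groups only 1-amino-1-methylethyl stands apart. Nothing measured here explains this difference. The compounds shown leave open whether the ring itself or the larger group matters. A 1-aminocyclopropyl group, or an open-chain 1-amino-1-ethylpropyl group, would bear on that.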